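From pyridin-4-yl to pyridin-3-yl on compound 1

A few compounds are considered here, and "the series" means these few. Any claim that something is new, unique, unknown or untested is made for them only; others in the source may bear on it.

In a physicochemical assay for solubility, in phosphate buffer (a lower number here means a less soluble compound, a higher number a more soluble compound), compound 1 `CC(=O)c1cccc(Nc2cc(C)nc(-c3ccncc3)n2)c1` gives 29000 nM. Compound 2 `CC(=O)c1cc(Nc2cc(C)nc(-c3ccncc3)n2)ccc1F` gives 23000 nM, within the scatter of compound 1. Going by the values given here, this is the only measured step, a 1.3-fold lower number from compound 1 to compound 2 (0.10 log units; within the scatter), and it swaps hydrogen for fluoro on an aromatic carbon, elsewhere in the molecule. Compound 3 `CC(=O)c1cccc(Nc2cc(C)nc(-c3cccnc3)n2)c1` differs from compound 1 in another way: pyridin-3-yl in place of pyridin-4-yl on an aromatic carbon. Among the compounds with values here, no measured step touches that group, so no shift beyond the scatter is expected in this assay. The expected step is a 1.2-fold lower number from compound 1 to compound 3 (0.06 log units; within the scatter). For compound 3 the estimated value is 25000 nM, within an expected range of 9000 nM to 70000 nM.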

Compound 3, solubility: 95000 nM
Compound 3: middle estimate off by 3.8-fold (0.58 log units), on the low side; the whole stated range lies below it.
By their numbers in this assay, from the lowest: compounds 2 and 1 (each within the scatter of the next); then compound 3.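

In this assay pyridin-3-yl in place of pyridin-4-yl gives a 3.3-fold higher number from compound 1 to compound 3 (0.52 log units; beyond the scatter) and so shows that this position responds to where the ring nitrogen sits, even though the atoms stay the same. The fluoro change elsewhere in the molecule stayed within the scatter, so this is the first step shown that goes beyond it. No measurement here accounts for the shift. Still open, from the compounds shown here alone, is how a plain phenyl or pyridin-2-yl would read at this position, and whether an amine on that ring would move the number further.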